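The source may hold more compounds than are shown below. What is called first, only, known or untested is meant among the compounds shown, and "the series" means these compounds.

Working notes on the series.

The shared core is seen in compound 1 `COC(=O)c1cc(C)ccc1-c1ccncc1`, which in an assay for inhibition of cholesterol 24-hydroxylase (Homo sapiens), using NADPH, with stated times of 15 min and 5 min (a lower number here means a stronger inhibitor, a higher number a weaker inhibitor), gives 1900 nM. Compound 2 `Cc1ccc(-c2ccncc2)c(C(=O)N2CCC(Cc3ccccc3)CC2)c1` gives 110 nM in this assay, and compound 3 `Cc1ccc(-c2ccncc2)c(C(=O)N2CCC(O)CC2)c1` gives 7700 nM. Compound 3 stands highest of the three numbers: the step of a 4.1-fold higher number from compound 1 to compound 3 (0.61 log units; beyond the scatter) is beyond the scatter, and the step of a 70-fold higher number from compound 2 to compound 3 (1.85 log units; beyond the scatter) is beyond it as well, so compound 3 is the weakest inhibitor shown.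

Compound 4 `CCC1(O)CCN(C(=O)c2cc(C)ccc2-c2ccncc2)CC1` differs from compound 3 by ethyl in place of hydrogen on a saturated ring carbon. The step that bears on this change is a 70-fold higher number from compound 2 to compound 3 (1.85 log units; beyond the scatter), where a large group on that same saturated ring carbon went with a far lower number. The ethyl group entering in compound 4 is a smaller addition than the benzyl of compound 2, and the hydroxy stays in place, so only part of that effect is expected.

Compound 4 is therefore expected to give a step of a 3.1-fold lower number from compound 3 to compound 4 (0.49 log units; beyond the scatter) in this assay, a modest lowering of the number. The estimate for compound 4 is 2500 nM, with a range from 800 nM to 8000 nM.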

Compound 4, half-maximal inhibitory concentration: 540 nM
Compound 4: the middle estimate sits 4.6-fold (0.67 log units) above what was measured, and the stated range ends above it.
By their numbers in this assay, from the lowest: compound 2; then compound 4; then compound 1; then compound 3.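

In this assay, within the data shown here, the step of a 14-fold lower number from compound 3 to compound 4 (1.15 log units; beyond the scatter) shows that the number can fall sharply through a change at this saturated ring carbon while the hydroxy stays in place, which the earlier compounds could not show. The entering ethyl has no ring and only 2 heavy atoms, so a large step at this position does not depend on a group as big as the benzyl of compound 2.

Still open, as far as these compounds go, is how the number would move with a longer chain such as propyl on this carbon, or with an amine in place of the hydroxy beside the ethyl, and how much the hydroxy itself matters once the ethyl is present. What lies behind the step also stays open, with no measurement at hand that bears on it.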